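The source may hold more compounds than are shown below. What is called first, only, known or untested is meant among the compounds shown, and "the series" means these compounds.

In a functional assay on MCF7 cells (Homo sapiens) for antiproliferative activity, read by fluorescence, with a stated time of 3 days; a lower number here means a stronger inhibitor, a higher number a weaker inhibitor:

Compound 1 `Clc1ccccc1Nc1nc(SCCc2ccccc2)nc2[nH]ncc12`: 19200 nM
Compound 2 `CCCCCSc1nc(Nc2ccccc2Cl)c2cn[nH]c2n1`: 19200 nM

On these numbers, compound 1 stands level with compound 2 at the digits shown. Compound 3 `O=[N+]([O-])c1cccc(Nc2nc(SCCc3ccccc3)nc3[nH]ncc23)c1` has not yet been measured in this assay. It carries 3-nitrophenyl in place of 2-chlorophenyl on a nitrogen on an aromatic ring. Within the data shown here, the only measured step is no change at the digits printed from compound 1 to compound 2 (within the scatter), and it swaps propyl for phenyl on the saturated chain, leaving the group on that nitrogen untouched. Among the measured compounds shown here, it therefore bears only indirectly on this change, and no measured pair varies that group. The data set no direction, so the expectation stays anchored on compound 1 at 19200 nM. The expected outcome is a 1.2-fold lower number from compound 1 to compound 3 (0.08 log units; within the scatter), an estimated step no larger than the scatter. Compound 3 is estimated at 16000 nM, with an expected range from 5000 nM to 50000 nM.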

Compound 3, half-maximal inhibitory concentration: 19200 nM
The estimate for compound 3 lay 1.2-fold (0.08 log units) below the measured number; the measured number falls inside the stated range.
By their numbers in this assay, from the lowest: compounds 1, 2 and 3 (each within the scatter of the next).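

In this assay, among these compounds, the step that swaps 2-chlorophenyl for 3-nitrophenyl on a nitrogen on an aromatic ring gives no change at the digits printed from compound 1 to compound 3 (within the scatter), and it is the first measured variation of that group. Here the read-out does not separate the two groups, although 3-nitrophenyl has more heavy atoms and carries hydrogen-bond acceptors while 2-chlorophenyl carries none, so this change joins the chain change in leaving all three compounds within the scatter. No measurement shown accounts for this result.

The two groups differ both in the substituent and in its numbered place on the ring, so the compounds shown cannot separate those two changes, which 3-chlorophenyl or 2-nitrophenyl could do. Also open, going by these compounds, is whether an unsubstituted phenyl, or an aminophenyl or carboxyphenyl, on that nitrogen would shift the number at all.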